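The compounds below may be only part of what the source reports. "The series", "measured", "known", "first", "only" and "open" are said of these compounds alone.

Measured so far:
- compound 1, `CC(C)=CCCC1=CC[C@H](C(=O)N(C)O)[C@@H](c2ccccc2)C1`: 2100 nM
- compound 2, `COc1ccc(NC(=O)[C@H]2CC=C(CCC=C(C)C)C[C@@H]2c2ccccc2)cc1`: > 23000 nM

Within the data shown here, in an assay on isolated protein for inhibition of Apoptosis regulator Bcl-2 (Homo sapiens), read by fluorescence polarization, with stated times of 5 min and 10 min (on this read-out lower numbers stand for stronger inhibition and higher numbers for weaker inhibition), compound 1 gives 2100 nM and is the only compound of the pair with a number rather than a limit. Compound 2 reaches only a limit of the assay, > 23000 nM; this is the limit noted as the limit of > 23000 nM in this assay, at which 1 of the 2 values shown sits. Among the measured compounds shown here, the one measured step, an at least 10-fold higher number from compound 1 to compound 2 (1.03 log units; beyond the scatter), is large, and it concerns the group on the carbonyl carbon, not the configuration of the core.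

Compound 3, `CC(C)=CCCC1=CC[C@@H](C(=O)N(C)O)[C@H](c2ccccc2)C1`, is next to be measured. It differs from compound 1 as follows: the two compounds have the same atoms and bonds and differ only in configuration as drawn: 2 of 2 stereo elements differ (all stereocentres are inverted: mirror images); a stereocentre at a saturated ring carbon is drawn S in compound 1 and R in compound 3; a stereocentre at a saturated ring carbon is drawn S in compound 1 and R in compound 3. No measured step touches a change of configuration, so the step from compound 1 to compound 3 has no direct precedent among these compounds; the step from compound 1 to compound 2 shows only that the series is sensitive to change at one place, not how it responds to inversion of both centres. An inversion of both stereocentres is expected to move the number in this assay, most likely towards weaker inhibition, but the direction and size are uncertain and a result within the scatter cannot be excluded. The estimated step is a 2.9-fold higher number from compound 1 to compound 3 (0.46 log units; beyond the scatter). Compound 3 is expected to give 6000 nM, with a range from 1500 nM to 25000 nM.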

Compound 3, inhibition constant: 2300 nM
Compound 3: middle estimate off by 2.6-fold (0.42 log units), on the high side; measured number inside the range.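

In this assay, inverting both stereocentres gives a 1.1-fold higher number from compound 1 to compound 3 (0.04 log units; within the scatter), so this mirror-image pair cannot be told apart on this read-out, and the configuration drawn at the two saturated ring carbons does not by itself set the number here. The only large step among the compounds shown remains an at least 10-fold higher number from compound 1 to compound 2 (1.03 log units; beyond the scatter), so among these compounds the number responds to the replacement of the hydroxy(methyl)amino group on the carbonyl carbon and not to the inversion of both centres. The comparison isolates configuration, with no atom or bond entering or leaving: the fact that compounds 1 and 3 differ only in the configuration as drawn.

Open questions are whether inverting only one of the two centres, which would change the relation between the carbonyl-bearing carbon and the phenyl-bearing carbon, gives the same result as inverting both, and whether the indifference to configuration also holds with other groups on the carbonyl carbon. A carboxylic acid or a plain methylamino group at that carbon, or a shorter chain in place of the side chain on the core, would show how much of the number depends on each part of compound 1.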